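Replacing methoxy with phenyl in compound 2

This account rests on a few compounds, and the source may have more. Where it says the series, first, only, none or still open, it means among the compounds named here.

In a functional assay on KB cells (Homo sapiens) for antiproliferative activity, read by colorimetric assay and MTT assay (a higher number here means a weaker inhibitor, a lower number a stronger inhibitor), compound 1 (`Nc1ccc(S(=O)(=O)Nc2ccc(Br)c3c(Cl)c[nH]c23)cc1`) gives 13 ug/mL and compound 2 (`COc1ccc(NS(=O)(=O)c2ccc(N)cc2)c2[nH]cc(Cl)c12`) gives 20 ug/mL. These two values cannot be told apart, so compound 2 stands level with compound 1. Compound 3 (`Nc1ccc(S(=O)(=O)Nc2ccc(-c3ccccc3)c3c(Cl)c[nH]c23)cc1`) keeps the shared core and carries phenyl in place of methoxy on an aromatic carbon. Among the compounds with values here, one measured step bears on this place, methoxy in place of bromo, which runs a 1.5-fold higher number from compound 1 to compound 2 (0.19 log units; within the scatter) and lies within the scatter. No ring-bearing group has been measured there, so the guidance for phenyl is indirect. Resting on compound 2 at 20 ug/mL and that single small step, no change beyond the scatter is expected in this assay, though with wide uncertainty. The estimated step runs a 1.4-fold lower number from compound 2 to compound 3 (0.15 log units; within the scatter). The estimate for compound 3 is 14 ug/mL, with an expected range of 4 ug/mL to 40 ug/mL.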

Compound 3, half-maximal inhibitory concentration: 15 ug/mL
The estimate for compound 3 lay 1.1-fold (0.03 log units) below the measured number, and the stated range covers the measured number.
By their numbers in this assay, from the lowest: compounds 1, 3 and 2 (each within the scatter of the next).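

Phenyl is the first ring-bearing group seen at this place, and in this assay its entry leaves the number within the scatter, with a 1.3-fold lower number from compound 2 to compound 3 (0.12 log units; within the scatter). Set against bromo, the same group gives a 1.2-fold higher number from compound 1 to compound 3 (0.06 log units; within the scatter), also within the scatter, so bromo, methoxy and phenyl stand level on this aromatic carbon, even though phenyl brings six heavy atoms and a six-membered aromatic ring of carbon only. No measurement at hand offers a reason for this levelness.

The compounds shown leave open whether an amine or a carboxylic acid on this carbon would move the number beyond the scatter. They also leave open whether a longer chain or a phenyl ring bearing a fluoro group would do so.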